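This account rests on a few compounds, and the source may have more. Where it says the series, first, only, none or still open, it means among the compounds named here.

Measured compounds:
compound 1, `N#Cc1ccc(S(=O)(=O)Nc2ccc(Cl)c3cc[nH]c23)cc1`, 15 ug/mL in a functional assay on KB cells (Homo sapiens) for antiproliferative activity, read by colorimetric assay and MTT assay; a higher number here means a weaker inhibitor, a lower number a stronger inhibitor;
compound 2, `N#Cc1ccc(S(=O)(=O)Nc2ccc(Cl)c3c(Cl)c[nH]c23)cc1`, 13 ug/mL in this assay;
compound 3, `Nc1ccc(S(=O)(=O)Nc2cccc3cc[nH]c23)cc1`, 36 ug/mL in this assay.

Compounds 1 and 2 share a core and differ in one place: chloro in place of hydrogen on an aromatic carbon. The step this change made in this assay was a 1.2-fold lower number from compound 1 to compound 2 (0.06 log units; within the scatter), so the two numbers for compound 1 and compound 2 cannot be told apart. Compound 3 is built on a different core; how the two cores differ is not broken down here. In this assay compound 3 gives the highest number of the three.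

Compound 4, `Nc1ccc(S(=O)(=O)Nc2cccc3cc(Cl)[nH]c23)cc1`, has not been measured. It differs from compound 3 in one place: chloro in place of hydrogen on an aromatic carbon. Among the compounds with values here, this is the same kind of change as the one from compound 1 to compound 2, but the place is not the same: in compound 2 the chloro sits two ring bonds from the ring nitrogen, whereas in compound 4 it sits next to the ring nitrogen.

Within the data shown here, the only guide to the size of the step is that from compound 1 to compound 2, which was within the scatter. For compound 4 the expected step in this assay is therefore a 1.2-fold lower number from compound 3 to compound 4 (0.08 log units; within the scatter), because the same kind of change gave a 1.2-fold lower number from compound 1 to compound 2 (0.06 log units; within the scatter). Compound 4 is estimated at 30 ug/mL, with a range from 14 ug/mL to 65 ug/mL, the width reflecting that the place of the chloro differs from the measured pair.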

Compound 4, half-maximal inhibitory concentration: 1.4 ug/mL
Beside the measured number, compound 4's estimate is 21-fold (1.33 log units) above it; the measured number lies below the stated range.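

In this assay, chloro in place of hydrogen on an aromatic carbon gave a 26-fold lower number from compound 3 to compound 4 (1.41 log units; beyond the scatter), so in this series the size of the step did not carry over from one pair to the other: the same change on two cores in this assay, a 1.2-fold lower number (0.06 log units; within the scatter) from compound 1 to compound 2 and a 26-fold lower number (1.41 log units; beyond the scatter) from compound 3 to compound 4, 22-fold (1.35 log units) apart, beyond the scatter of two such steps

This does not show whether the difference comes from the core or from the place of the chloro, since the two pairs differ in both, and in compound 4 the chloro sits next to the ring nitrogen while in compound 2 it sits elsewhere. The comparison rests on just these two pairs, so it gives no general rule for the change and says nothing about how the chloro produces the large step on the core of compound 3.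

The compounds shown leave open whether a chloro next to the ring nitrogen on the core of compound 1 would give a step as large, and whether a chloro placed as in compound 2 on the core of compound 3 would give a step as small. They also leave open whether the large step is specific to chloro, or whether a bromo or a methyl group next to the ring nitrogen on the core of compound 3 would give a similar one.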